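From a Fluorinated Sugar to a Mesylate: Compound 4

The source may hold more compounds than are shown below. What is called first, only, known or untested is meant among the compounds shown, and "the series" means these compounds.

Compound 1, `Cc1ccc(S(=O)(=O)O[C@@H]2[C@@H](O)[C@H](n3cc(F)c(N)nc3=O)O[C@@H]2CO)cc1`: 3.9 ug/mL
Compound 2, `Cc1ccc(S(=O)(=O)O[C@@H]2[C@@H](O)[C@H](n3ccc(N)nc3=O)O[C@@H]2CO)cc1`: > 30 ug/mL
Compound 3, `Nc1ccn([C@@H]2O[C@H](CO)[C@H](F)[C@H]2O)c(=O)n1`: > 100 ug/mL

All three were tested in a functional assay on P815 cells (Mus musculus) for antiproliferative activity; a lower number here means a stronger inhibitor, a higher number a weaker inhibitor. Compound 1 gives 3.9 ug/mL. For compound 2 the value > 30 ug/mL is a limit of the assay, not a number (the limit of > 30 ug/mL in this assay, at which 1 of the 3 values shown sits). For compound 3 the value > 100 ug/mL is also a limit (the limit of > 100 ug/mL in this assay, at which 1 of the 3 values shown sits). Compound 3 thus stands at the weak end of what is shown, with no number at all.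

Going by the values given here, the only measured step is an at least 7.6-fold higher number from compound 1 to compound 2 (0.88 log units; beyond the scatter), the exchange of hydrogen in place of fluoro on an aromatic carbon, and it was at least modest.

Compound 4, `CS(=O)(=O)O[C@@H]1[C@@H](O)[C@H](n2ccc(N)nc2=O)O[C@@H]1CO`, differs from compound 3 by (methylsulfonyl)oxy in place of fluoro on a saturated ring carbon. Among the compounds with values here, no measured step covers this change. Compound 4 shares its base with compound 2, and compound 2 reached only a limit in this assay, while compound 3 itself is a limit. The expected step is therefore an at least 1.2-fold lower number from compound 3 to compound 4 (0.09 log units; that floor lies within the scatter), with a high chance that compound 4 again reports only a limit. Compound 4 is estimated at 80 ug/mL, within 25 ug/mL to 300 ug/mL.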

Compound 4, concentration for 50% inhibition: 22 ug/mL
Compound 4: the middle estimate sits 3.6-fold (0.56 log units) above what was measured; the whole stated range lies above it.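

Going by these compounds alone, compound 4 is the first compound without the aromatic fluoro to give a number rather than a limit in this assay, and (methylsulfonyl)oxy in place of fluoro on this saturated ring carbon gives an at least 4.5-fold lower number from compound 3 to compound 4 (0.65 log units; beyond the scatter). Methyl in place of 4-methylphenyl on the sulfonyl sulfur gives an at least 1.3-fold lower number from compound 2 to compound 4 (0.13 log units; that floor lies within the scatter), so the 4-methylphenyl group is not shown to be required for activity at this position, and no firm gain is shown for methyl either. Both steps start from a limit, so each gives only a floor.

As far as these compounds go, it remains open whether an aromatic fluoro would lower the number for the methylsulfonyl compound as it does in the 4-methylphenyl pair. Also open, from the compounds shown here alone, is how an amine at this ring carbon, or an ethyl or longer chain on the sulfonyl sulfur, would read in this assay.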